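The compounds below may be only part of what the source reports. "The series", "measured", "known", "first", "only" and "open" are said of these compounds alone.

Compound 1 `CC(=O)Nc1cc(-c2c(Nc3cc[nH]n3)nc3ccccn23)nc(C)n1` was run in an in vivo ADME assay on the whole organism for pharmacokinetics, with Rattus norvegicus as the target, at a dose of 0.5 mg/kg by the intravenous route (on this read-out lower numbers stand for narrower distribution and higher numbers for wider distribution into tissues), and in that test compound 1 gives 1.2 L/kg. Compound 2 `Cc1nccc(-c2c(Nc3cc[nH]n3)nc3cccnn23)n1` gives 0.62 L/kg in this assay. For the measured compounds named here, those are the only two numbers in hand, and the gap between them lies within the scatter, so the two compounds cannot be told apart on this read-out. Going by the values given here, no single-change step between measured compounds has been recorded. Compound 3 `CC(=O)Nc1cc(-c2c(Nc3ccn(C)n3)nc3ccccn23)nc(C)n1` differs from compound 1 by methyl in place of hydrogen on an aromatic nitrogen, a methyl in place of hydrogen on an aromatic nitrogen. Among the compounds with values here, with no measured step of this type to lean on, the step from compound 1 to compound 3 in this assay is expected to be small, at most a modest widening, a 1.3-fold higher number from compound 1 to compound 3 (0.10 log units; within the scatter), and may not exceed the scatter. Compound 3 is therefore estimated at 1.5 L/kg, with a range from 0.8 L/kg to 2.8 L/kg.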

Compound 3, volume of distribution at steady state: 0.6 L/kg
Beside the measured number, compound 3's estimate is 2.5-fold (0.40 log units) above it, and the stated range ends above it.
By their numbers in this assay, from the lowest: compounds 3, 2 and 1 (each within the scatter of the next).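

With 1H-pyrazol-3-yl replaced by 1-methyl-1H-pyrazol-3-yl on the core of compound 1, this assay gives its first single-change step, which is a 2.0-fold lower number from compound 1 to compound 3 (0.30 log units; within the scatter) and so does not separate the two compounds. At this aromatic nitrogen, then, methyl in place of hydrogen leaves the read-out within the scatter, something compound 2 could not show, since it differs from compound 1 in more than one place. Nothing in hand bears on what lies behind this step. 

On these data alone, whether a larger group on this nitrogen, such as an ethyl, a longer chain or a chain ending in an amine, would give a step beyond the scatter stays open. So does whether the same methyl step would read alike on the core of compound 2.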